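Aminocoumarin series: aniline swap from compound 2 to compound 3

The compounds below may be only part of what the source reports. "The series", "measured", "known", "first", "only" and "open" are said of these compounds alone.

Measured so far:
- compound 1 `COc1ccc(-c2c(Nc3ccc(C)c(O)c3)c3ccc(OC)cc3oc2=O)cc1`: 31300 nM
- compound 2 `COc1ccc(-c2c(Nc3ccc(C)c(O)c3)c3ccc(O)cc3oc2=O)cc1`: "not determined" (no result reported)

Compound 1 is the only one of the series with a number; in a functional assay on PANC-1 cells (Homo sapiens) for antiproliferative activity, read by MTT assay, with a stated time of 48 h (on this read-out higher numbers stand for weaker inhibition and lower numbers for stronger inhibition), compound 1 gives 31300 nM, a weak result. Among the measured compounds shown here, compound 2 differs from it only on the shared core, and in this assay compound 2 gives "not determined" (no result reported), so there is no measured step and no place for compound 2 on the scale.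

Compound 3 `COc1ccc(-c2c(Nc3cccc(C(F)(F)F)c3)c3ccc(O)cc3oc2=O)cc1` is the next entry. Relative to compound 2 the change is 3-(trifluoromethyl)phenyl in place of 3-hydroxy-4-methylphenyl on a nitrogen on an aromatic ring. For the measured compounds named here, no step between measured compounds exists from which a direction could be read; on this assay the step from compound 2 to compound 3 is expected to be of modest size, without a firm direction, and may well fall within the scatter.

For compound 3 in this assay the estimate is 25000 nM, with a range from 6000 nM to 90000 nM, anchored on the weak result of compound 1 31300 nM.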

Compound 3, half-maximal inhibitory concentration: 67200 nM
Compound 3: the middle estimate sits 2.7-fold (0.43 log units) below what was measured; the range from low to high includes it.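

Compound 2 has no number to set against compound 3, so no step can be read from this result. The compounds shown leave open which way the change from 3-hydroxy-4-methylphenyl to 3-(trifluoromethyl)phenyl moves activity. No supporting measurement bears on the result.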